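The compounds below may be only part of what the source reports. "The series", "measured", "known", "first", "only" and "open" are said of these compounds alone.

Compound 1 (`COc1ccc(-c2c(C#N)c(-c3ccccc3)nc3c2c(-c2cccnc2)nn3-c2ccccc2)cc1`) is the unsubstituted member of this small series. In a functional assay on HepG2 cells (Homo sapiens) for cytotoxicity, read by colorimetric assay (on this read-out lower numbers stand for stronger inhibition and higher numbers for weaker inhibition), compound 1 is reported as "not active" (no number reported) with no number, so it gives no fixed point from which to count a step. Two close relatives do have numbers. In this assay compound 2 (`COc1ccc(-c2c(C#N)c(-c3ccc(C)cc3)nc3c2c(-c2cccnc2)nn3-c2ccccc2)cc1`) gives 4.34 ug/mL and compound 3 (`COc1ccc(-c2c(C#N)c(-c3ccc(F)cc3)nc3c2c(-c2cccnc2)nn3-c2ccccc2)cc1`) gives 3.43 ug/mL in the same test.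

The change to follow leads to compound 4 (`COc1ccc(-c2c(C#N)c(-c3ccc([N+](=O)[O-])cc3)nc3c2c(-c2cccnc2)nn3-c2ccccc2)cc1`). It is nitro in place of hydrogen on an aromatic carbon, para to a large group, which turns phenyl into 4-nitrophenyl (nitro in place of hydrogen on an aromatic carbon). For the measured compounds named here, the only measured step at this place is a 1.3-fold lower number from compound 2 to compound 3 (0.10 log units; within the scatter) with fluoro in place of methyl. Swapping one group for the other therefore moved the number by no more than the scatter, and both compounds with a group there have numbers, unlike compound 1. Nitro has not been tested here, so this is a guide and not a rule.

In this assay a measurable number is expected, in the direction of stronger inhibition than compound 1 shows. With compound 2 at 4.34 ug/mL as the reference, the number is expected to stay within the scatter. For compound 4 the estimated value is 4 ug/mL with an expected range from 1.5 ug/mL to 11 ug/mL as its ends.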

Compound 4, half-maximal inhibitory concentration: 13.5 ug/mL
Beside the measured number, compound 4's estimate is 3.4-fold (0.53 log units) below it; measured number above the stated range.
By their numbers in this assay, from the lowest: compounds 3 and 2 (each within the scatter of the next); then compound 4.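

In this assay the earlier swap at this position moved the number by no more than the scatter, which left open whether the choice of group there mattered at all, so long as one was present. Nitro shows that it can, with a 3.9-fold higher number from compound 3 to compound 4 (0.60 log units; beyond the scatter) and a 3.1-fold higher number from compound 2 to compound 4 (0.49 log units; beyond the scatter) both beyond the scatter, though both are modest in size. Compound 4 also still gives a number, so methyl, fluoro and nitro at this place all give one, while compound 1, with only hydrogen there, is reported without one, and nothing measured here accounts for either observation.

On these data alone, it remains open whether nitro stands apart from the other groups or is one point on a wider spread, which an amine, a carboxylic acid or a longer chain such as butyl at the same place would help to settle. It is also unknown whether a second halogen such as chloro would stay close to compound 3 or move toward compound 4.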